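The source may hold more compounds than are shown below. What is called first, only, known or untested is meant among the compounds shown, and "the series" means these compounds.

Of the compounds shown here, two with the same core have been measured in a functional assay on EC9706 cells (Homo sapiens) for antiproliferative activity, read by MTT assay, with a stated time of 72 h; on this read-out higher numbers stand for weaker inhibition and lower numbers for stronger inhibition. Compound 1 `C/C(=N\NC(=O)c1cccc(S(=O)(=O)N2CCOCC2)c1)c1ccccc1O` carries a 2-hydroxyphenyl group on its carbon double-bonded to nitrogen, and in this assay compound 1 gives 1220 nM. Compound 2 `O=C(N/N=C/c1ccco1)c1cccc(S(=O)(=O)N2CCOCC2)c1` carries a furan-2-yl group at the same place. For compound 2 the assay gives no number but only a limit, > 100000 nM, and this is the limit of > 100000 nM in this assay, at which 1 of the 2 values shown sits. Compound 2 therefore stands at the weak end of what the assay can report, while compound 1 sits well inside the measurable range.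

Compound 3 `O=C(N/N=C/c1ccccc1O)c1cccc(S(=O)(=O)N2CCOCC2)c1` has not yet been measured. It differs from compound 2 in one place: 2-hydroxyphenyl in place of furan-2-yl on a carbon with a double bond to nitrogen. Compound 3 thus carries the same 2-hydroxyphenyl group as compound 1, and differs from compound 1 only in lacking a methyl on that same carbon.

Since compound 1 with the 2-hydroxyphenyl group gives 1220 nM, the step of an at least 40-fold lower number from compound 2 to compound 3 (1.60 log units; beyond the scatter) is expected to be a large gain in potency, well beyond the usual scatter. Compound 3 is expected to reach about 2500 nM, within a range from 500 nM to 20000 nM.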

Compound 3, half-maximal inhibitory concentration: 19600 nM
Compound 3: middle estimate off by 7.8-fold (0.89 log units), on the low side; the measured number falls inside the stated range.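

Replacing furan-2-yl with 2-hydroxyphenyl on a carbon with a double bond to nitrogen moves the result from a limit to a measured number in this assay, with an at least 5.1-fold lower number from compound 2 to compound 3 (0.70 log units; beyond the scatter), so the group at this place matters even without the methyl of compound 1. Among these compounds, for compound 2 the value > 100000 nM is a limit and not a number, so the true size of this step stays unknown because the weak end of the assay hides it: the limit of > 100000 nM in this assay, at which 1 of the 3 values shown sits. Compound 3 and compound 1 also form the first pair that differs only by a methyl on that same carbon: compound 3 gives 19600 nM and compound 1 gives 1220 nM, so the lower number goes with the methyl.

The compounds shown leave open whether the gain belongs to the hydroxyl or to the six-membered aromatic ring itself, which a plain phenyl group or a methoxyphenyl group at this place would help to separate. Also open, on these data alone, is whether a longer chain such as ethyl in place of that methyl would lower the number further, and how furan-2-yl behaves when the methyl is present.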